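The compounds below may be only part of what the source reports. "The series", "measured", "known", "first", "only" and "open" are said of these compounds alone.

Measured in a functional assay on NCI-H460 cells (Homo sapiens) for cytotoxicity, read by MTT assay, with a stated time of 72 h; on this read-out lower numbers stand for stronger inhibition and higher numbers for weaker inhibition:

compound 1, `COc1cc2c(Oc3ccc(NC(=O)c4cc(-c5ccc(F)cc5)ccn4)cc3F)ccnc2cc1OCCCN1CCCCC1`: 250 nM
compound 2, `COc1cc2c(Oc3ccc(NC(=O)c4cc(-c5ccccc5C)ccn4)cc3F)ccnc2cc1OCCCN1CCN(C)CC1`: 150 nM
compound 3, `COc1cc2c(Oc3ccc(NC(=O)c4cc(-c5ccc(F)cc5)ccn4)cc3F)ccnc2cc1OCCCN1CCN(C)CC1`: 430 nM

Compound 3 carries the highest of the three numbers. Its gap to compound 1 is small, a 1.7-fold higher number from compound 1 to compound 3 (0.24 log units; within the scatter), and that pair differs only in the amine at the end of the chain. Its gap to compound 2 is larger, a 2.9-fold higher number from compound 2 to compound 3 (0.46 log units; beyond the scatter), and that pair differs only in the aryl group on the shared core, 4-fluorophenyl in place of 2-methylphenyl.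

Compound 4, `COc1cc2c(Oc3ccc(NC(=O)c4cc(-c5ccc(C(F)(F)F)cc5)ccn4)cc3F)ccnc2cc1OCCCN1CCN(C)CC1`, comes from compound 3 by a change at that same aryl group: trifluoromethyl in place of fluoro on an aromatic carbon. Within the data shown here, only the step from compound 2 to compound 3 touches this position, and it was modest; no measured step exchanges fluoro for trifluoromethyl anywhere, so the direction of the new step cannot be read from these data. Compound 4 is therefore expected to land near compound 3 in this assay, with a step of a 1.1-fold lower number from compound 3 to compound 4 (0.03 log units; within the scatter) that is most likely within the scatter. The estimate for compound 4 is 400 nM, with a range from 150 nM to 1100 nM.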

Compound 4, half-maximal inhibitory concentration: 160 nM
Estimate against measurement, compound 4: 2.5-fold (0.40 log units) above, within the range that was stated.
By their numbers in this assay, from the lowest: compounds 2, 4, 1 and 3 (each within the scatter of the next, the first and the last beyond it).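

In this assay, exchanging fluoro for trifluoromethyl at the same aromatic carbon, para to a large group, gives a 2.7-fold lower number from compound 3 to compound 4 (0.43 log units; beyond the scatter), so this position responds to a change of substituent even when the substituent's place on the phenyl ring stays the same, which the earlier step could not show, as it also moved the substituent. Set against the 2-methylphenyl group, 4-(trifluoromethyl)phenyl gives a 1.1-fold higher number from compound 2 to compound 4 (0.03 log units; within the scatter), so two aryl groups with different substituents in different places cannot be told apart here. Among the three compounds with the 4-methylpiperazin-1-yl chain, compound 3 with its 4-fluorophenyl group is thus the one that stands apart from both others, and nothing shown here accounts for that difference.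

Left open is how a chloro, methoxy or nitrile group in the same place, or a phenyl ring with no substituent, would compare with fluoro and trifluoromethyl. Also open, from the compounds shown here alone, is whether the step from fluoro to trifluoromethyl would repeat on the core of compound 1, which carries piperidin-1-yl at the end of the chain.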